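A few compounds are considered here, and "the series" means these few. Any claim that something is new, unique, unknown or untested is made for them only; others in the source may bear on it.

Measured so far:
- Compound 1 `COc1ccc(-c2[nH]c3ccccc3c2C=O)cc1`: 180 nM
- Compound 2 `COc1ccc(-c2[nH]c3ccc(OC)cc3c2C=O)cc1`: 180 nM

In a functional assay on MCF7 cells (Homo sapiens) for antiproliferative activity, with a stated time of 5 days (on this read-out higher numbers stand for weaker inhibition and lower numbers for stronger inhibition), compound 2 gives 180 nM, level with compound 1 at 180 nM. The next candidate, compound 3 `COc1ccc(-c2[nH]c3ccc(OC)cc3c2C=C(C#N)C#N)cc1`, has not been measured. It differs from compound 2 by one change: 2,2-dicyanoethenyl in place of formyl on an aromatic carbon. This puts 2,2-dicyanoethenyl in place of formyl on an aromatic carbon.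

Among the measured compounds shown here, only one measured step is available, no change at the digits printed from compound 1 to compound 2 (within the scatter). It places methoxy in place of hydrogen on an aromatic carbon and leaves the formyl group untouched, so it bears only indirectly on this swap. For the measured compounds named here, no measured compound yet carries 2,2-dicyanoethenyl. With so little evidence, no step beyond the scatter is expected in this assay, though the uncertainty is wide. The estimated step is a 1.8-fold lower number from compound 2 to compound 3 (0.26 log units; within the scatter). For compound 3, the expected value is 100 nM, with an estimated range of 20 nM to 450 nM.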

Compound 3, half-maximal inhibitory concentration: 340 nM
Beside the measured number, compound 3's estimate is 3.4-fold (0.53 log units) below it, within the range that was stated.
By their numbers in this assay, from the lowest: compounds 1, 2 and 3 (each within the scatter of the next).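

In this assay, putting 2,2-dicyanoethenyl in place of formyl on an aromatic carbon of the five-membered aromatic ring gives a 1.9-fold higher number from compound 2 to compound 3 (0.28 log units; within the scatter). This is the first change shown at this position, as the step from compound 1 to compound 2 left formyl untouched. The entering group has 6 heavy atoms against 2 for formyl, yet the read-out stays within the scatter, so at this position formyl can be swapped for this larger group without a step beyond the scatter, and nothing measured here explains that result.

Still open, from the compounds shown here alone, is whether an amine, a carboxylic acid or a longer chain at this position would also stay within the scatter of compound 2. Also open, going by these compounds, is whether 2,2-dicyanoethenyl would behave the same way on the core of compound 1, without the added methoxy.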